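The compounds below may be only part of what the source reports. "The series", "measured", "known", "first", "only" and "open" are said of these compounds alone.

Compound 1 `COc1cc(OC)cc(OCC(=O)O)c1` gives 242000 ug/mL in an ADME assay for solubility; a lower number here means a less soluble compound, a higher number a more soluble compound. Compound 2 `COc1cc(OCC(=O)O)cc(OC)c1OC` gives 242000 ug/mL in this assay, so that no change at the digits printed from compound 1 to compound 2 (within the scatter) follows from methoxy in place of hydrogen on an aromatic carbon. The core of compound 3 `O=C(O)COCc1ccc(Cl)cc1` differs from the core of compound 1 in a way not broken down here. In this assay compound 3 gives 248000 ug/mL, and the values of compounds 1, 2 and 3 all sit within the scatter of one another. Compound 4 `COc1cc(Cl)ccc1COCC(=O)O` is not yet measured; it arises from compound 3 by methoxy in place of hydrogen on an aromatic carbon, the same kind of change as from compound 1 to compound 2, but ortho to a group of 6 heavy atoms and meta to a chloro group rather than ortho to two methoxy groups and para to a carboxymethoxy group. For compound 4 the step of a 1.0-fold lower number from compound 3 to compound 4 (0.01 log units; within the scatter) is expected to stay within the scatter, because no change at the digits printed from compound 1 to compound 2 (within the scatter) was seen for the earlier case. Compound 4 is estimated at 240000 ug/mL, between 120000 ug/mL and 480000 ug/mL, in this assay.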

Compound 4, solubility: 240000 ug/mL
Beside the measured number, compound 4's estimate shows no gap at the digits printed, within the range that was stated.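

Methoxy in place of hydrogen on an aromatic carbon gives a 1.0-fold lower number from compound 3 to compound 4 (0.01 log units; within the scatter) in this assay, and the change reads alike on the two cores: the same change on two cores in this assay, no change at the digits printed (within the scatter) from compound 1 to compound 2 and a 1.0-fold lower number (0.01 log units; within the scatter) from compound 3 to compound 4, 1.0-fold (0.01 log units) apart, within the scatter of two such steps.
In this series, then, the absence of a measurable step carries from the core of compound 1 to the core of compound 3, including the place ortho to a group of 6 heavy atoms and meta to a chloro group. This rests on two cores only and does not show that the change would stay within the scatter on other cores or at other places on the ring.

Still open, going by these compounds, is whether an amine or a trifluoromethyl group on the same aromatic carbon would read alike on both cores. Also open, on these data alone, is how the methoxy step would read on a core carrying an amide in place of the carboxylic acid.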